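A Methyl in Place of Hydrogen on Compound 1

The source may report more compounds than this note shows. Statements on the series, on what has been measured and on what is new or still open speak of the compounds shown alone.

Compound 1 `c1ccc(C(c2c[nH]c3ccccc23)c2c[nH]c3ccccc23)cc1` is the starting point. In a functional assay on MCF7 cells (Homo sapiens) for inhibition, read by MTT assay, with a stated time of 48 h (on this read-out lower numbers stand for stronger inhibition and higher numbers for weaker inhibition), compound 1 gives 22200 nM. That lies within the scatter of compound 3 `CN(C)c1ccc(C(c2c[nH]c3ccc(Br)cc23)c2c[nH]c3ccc(Br)cc23)cc1`, which gives 24900 nM. Compound 2 `COc1ccc(OC)c(C(c2c[nH]c3ccc(Br)cc23)c2c[nH]c3ccc(Br)cc23)c1` gives 2800 nM, a number clearly lower than that of compound 1, which means stronger inhibition.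

Compound 4 `CC(c1ccccc1)(c1c[nH]c2ccccc12)c1c[nH]c2ccccc12` has not yet been measured. Its change from compound 1 is methyl in place of hydrogen on a saturated chain carbon bound to three aromatic carbons. Among the measured compounds shown here, only one measured step bears on this, and only loosely: an 8.9-fold higher number from compound 2 to compound 3 (0.95 log units; beyond the scatter), with 4-(dimethylamino)phenyl in place of 2,5-dimethoxyphenyl on a saturated chain carbon. That step shows that this assay can respond to a swap on such a carbon. However, it exchanges different groups, and no measured compound carries a methyl there. For the measured compounds named here, with no direct precedent, no step beyond the scatter is expected in this assay, in either direction, so the expectation stays anchored on compound 1 at 22200 nM. The expected change is a 1.1-fold lower number from compound 1 to compound 4 (0.05 log units; within the scatter). For compound 4 the estimated value is 20000 nM, with an expected range from 8000 nM to 50000 nM.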

Compound 4, half-maximal inhibitory concentration: 4000 nM
Estimate against measurement, compound 4: 5.0-fold (0.70 log units) above; measured number below the stated range.
By their numbers in this assay, from the lowest: compounds 2 and 4 (each within the scatter of the next); then compounds 1 and 3 (each within the scatter of the next).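

In this assay, adding a single methyl gives a 5.6-fold lower number from compound 1 to compound 4 (0.74 log units; beyond the scatter), so a change of just one heavy atom on a saturated chain carbon bound to three aromatic carbons is enough to shift the number beyond the scatter, in the direction of stronger inhibition. The earlier step, an 8.9-fold higher number from compound 2 to compound 3 (0.95 log units; beyond the scatter), exchanged one aromatic group for another on the chain carbon, whereas this change leaves the phenyl and the rest of the core of compound 1 untouched and replaces only the hydrogen on that carbon, showing that this hydrogen is itself a point where the read-out responds. Nothing available here explains why the methyl lowers the number.

Going by these compounds, whether an ethyl, a longer chain or a hydroxyl on the same carbon would lower the number as the methyl does remains open. Among the compounds shown here, also open is whether a methyl in place of that hydrogen would give a step of similar size on compound 2, which differs from compound 1 in its aromatic group and its core, as this single pair is the only evidence for the change.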